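Methoxy to hydroxy on the bis-trifluoromethyl urea

The source may report more compounds than this note shows. Statements on the series, on what has been measured and on what is new or still open speak of the compounds shown alone.

Compound 2 `COc1cc(-c2nn(-c3cccc(NC(=O)Nc4cc(C(F)(F)F)cc(C(F)(F)F)c4)c3)cc2-c2ccncc2)ccc1Cl` gives 869 nM in a functional assay on RXF 393 cells (Homo sapiens) for inhibition, read by sulforhodamine B assay, with a stated time of 48 h (a lower number here means a stronger inhibitor of growth, a higher number a weaker inhibitor of growth), the second highest of the three numbers measured. Its nearest neighbour is compound 3 `COc1cc(-c2nn(-c3cccc(NC(=O)Nc4cccc(C(F)(F)F)c4)c3)cc2-c2ccncc2)ccc1Cl` with 777 nM, and the step of a 1.1-fold lower number from compound 2 to compound 3 (0.05 log units; within the scatter) is within the scatter. Among the measured compounds shown here, compound 1 `O=C(Nc1cccc(-n2cc(-c3ccncc3)c(-c3ccc(Cl)c(O)c3)n2)c1)Nc1cccc(C(F)(F)F)c1` gives 3020 nM, and a 3.9-fold lower number from compound 1 to compound 3 (0.59 log units; beyond the scatter) is the only measured step at the oxygen. Compound 4 `O=C(Nc1cccc(-n2cc(-c3ccncc3)c(-c3ccc(Cl)c(O)c3)n2)c1)Nc1cc(C(F)(F)F)cc(C(F)(F)F)c1` differs from compound 2 by hydrogen in place of methyl on an oxygen on an aromatic ring, the same change run in the opposite direction. That step bears directly on the prediction; the second trifluoromethyl, judged by a 1.1-fold lower number from compound 2 to compound 3 (0.05 log units; within the scatter), adds little. A modest rise in this assay is therefore expected, a 3.9-fold higher number from compound 2 to compound 4 (0.59 log units; beyond the scatter). Compound 4 is estimated at 3400 nM, with a range of 1500 nM to 7500 nM.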

Compound 4, concentration for 50% growth inhibition: 937 nM
Compound 4: the middle estimate sits 3.6-fold (0.56 log units) above what was measured, and the stated range ends above it.
By their numbers in this assay, from the lowest: compounds 3, 2 and 4 (each within the scatter of the next); then compound 1.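

With two trifluoromethyl groups on the urea, methoxy to hydroxy (a 1.1-fold higher number from compound 2 to compound 4 (0.03 log units; within the scatter)) does not show the loss seen with one, so in this assay the size of the step at this oxygen depends on the core: the same change on two cores in this assay, a 3.9-fold lower number (0.59 log units; beyond the scatter) from compound 1 to compound 3 and a 1.1-fold lower number (0.03 log units; within the scatter) from compound 4 to compound 2, 3.6-fold (0.56 log units) apart, beyond the scatter of two such steps
Read the other way, the second trifluoromethyl registers only on the hydroxy compounds (a 3.2-fold lower number from compound 1 to compound 4 (0.51 log units; beyond the scatter)): the same change on two cores in this assay, a 1.1-fold lower number (0.05 log units; within the scatter) from compound 2 to compound 3 and a 3.2-fold higher number (0.51 log units; beyond the scatter) from compound 4 to compound 1, 3.6-fold (0.56 log units) apart, beyond the scatter of two such steps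

These four compounds cover only methoxy and hydroxy at this oxygen, and only trifluoromethyl as the urea's substituent. From the compounds shown here alone, whether an ethoxy group or an amine in this place would show the same dependence on the core stays open.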